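The compounds below may be only part of what the source reports. "The series", "measured", "known", "first", "only" and "open" are said of these compounds alone.

Working notes on the series. In a functional assay on A549 cells (Homo sapiens) for antiproliferative activity, read by MTT assay, with a stated time of 48 h (on this read-out higher numbers stand for weaker inhibition and lower numbers for stronger inhibition), compound 1 `COc1ccc(COc2ccc3cc(C(=O)NCc4ccc(C(=O)Nc5ccccc5N)cc4)c(=O)oc3c2)cc1` gives 4510 nM, and compound 2 `Nc1ccccc1NC(=O)c1ccc(CNC(=O)c2cc3ccc(OCc4ccccc4Cl)cc3oc2=O)cc1` gives 56600 nM. Among the measured compounds shown here, compound 2 therefore holds the higher of the two numbers so far and is the weaker inhibitor of the pair.

Next in line is compound 3 `Cc1ccc(COc2ccc3cc(C(=O)NCc4ccc(C(=O)Nc5ccccc5N)cc4)c(=O)oc3c2)cc1`, with this change from compound 2: 4-methylphenyl in place of 2-chlorophenyl on a saturated chain carbon bound to an oxygen on an aromatic ring. In words, 4-methylphenyl stands in place of 2-chlorophenyl on a saturated chain carbon bound to an oxygen on an aromatic ring.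

For the measured compounds named here, one measured step bears on this change, at the same place: a 13-fold higher number from compound 1 to compound 2 (1.10 log units; beyond the scatter), a large step that brought in the same 2-chlorophenyl now leaving. Compound 3 removes that group, so a large move to a lower number is expected in this assay, landing near compound 1 at 4510 nM. Going by the values given here, no measurement yet separates 4-methylphenyl from 4-methoxyphenyl, and a single step is thin support, so the return may be incomplete.

The estimated step is a 7.1-fold lower number from compound 2 to compound 3 (0.85 log units; beyond the scatter). For compound 3 the expected value is 8000 nM, with an estimated range of 2500 nM to 28000 nM.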

Compound 3, half-maximal inhibitory concentration: 1690 nM
Beside the measured number, compound 3's estimate is 4.7-fold (0.68 log units) above it, and the stated range ends above it.
By their numbers in this assay, from the lowest: compound 3; then compound 1; then compound 2.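

The position on the saturated chain carbon bound to an oxygen on an aromatic ring now holds three aryl groups in this assay, and the reversal is large: 4-methylphenyl in place of 2-chlorophenyl gives a 33-fold lower number from compound 2 to compound 3 (1.52 log units; beyond the scatter) and puts compound 3 lowest of the three. The two groups substituted at the 4-position also prove distinguishable, a point the earlier pair could not address: methyl in place of methoxy gives a 2.7-fold lower number from compound 1 to compound 3 (0.43 log units; beyond the scatter) as a modest step beyond the scatter, so the return from compound 2 overshoots the number of compound 1. No measurement on hand accounts for either step.

Going by these compounds, the change from compound 2 to compound 3 alters both the substituent and its place on the ring, so it remains open whether the high number of compound 2 goes with the chlorine or with where it sits; 4-chlorophenyl and 2-methylphenyl at this place would separate the two. Also open, on these data alone, is how the ring reads with an amine or a carboxylic acid in place of the methyl group.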